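The compounds below may be only part of what the source reports. "The series", "measured", "known", "first", "only" and "open" are said of these compounds alone.

Three compounds were tested in a functional assay on PANC-1 cells (Homo sapiens) for cytotoxicity, read by WST assay, with a stated time of 24 h; a higher number here means a weaker inhibitor, a lower number a stronger inhibitor: compound 1 `O=C(/C=C/CCCCCCc1ccccc1)N[C@H]1CC[C@H](O)CC1`, compound 2 `O=C(CCCCCCc1ccccc1)N1CCCCC1` and compound 3 `Cc1ccc(CCCCCCCCC(=O)N2CCCCC2)cc1`. Compound 1 gives > 100000 nM, which is a limit and not a number. Compound 2 gives > 100000 nM, which is also a limit. Compound 3 gives > 100000 nM, again a limit, so it has no exact value and stands with the other two at the limit of > 100000 nM in this assay, at which 3 of the 3 values shown sit.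

The next compound, compound 4 `O=C(CCCCCCCCc1ccc(O)cc1)N1CCCCC1`, departs from compound 3 at one place, with 4-methylphenyl becoming 4-hydroxyphenyl: hydroxy in place of methyl on an aromatic carbon. This is hydroxy in place of methyl on an aromatic carbon, para to a large group. For the measured compounds named here, no measured pair shows what a single change does in this assay, so no step beyond the scatter is expected in either direction. The expected change, a number no higher from compound 3 to compound 4 (the limit leaves the size open), is therefore small. That expectation rests on compound 3, whose > 100000 nM is a limit. Compound 4 is estimated at 100000 nM, with an expected range of 40000 nM to 200000 nM.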

Compound 4, half-maximal inhibitory concentration: > 100000 nM
Compound 4 ended at the assay's limit; the forecaster's own chance of this, stated with the estimate: 80%; the middle value sits exactly at the limit.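

No step can be read between compound 3 and compound 4, as both stand at a limit in this assay: the limit of > 100000 nM in this assay, at which 4 of the 4 values shown sit. The compounds shown leave open whether any change to these structures would give an exact value in this assay.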